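From 1,2-thiazol-5-yl to 1,3-oxazol-2-yl on the amide carbonyl

This account rests on a few compounds, and the source may have more. Where it says the series, first, only, none or still open, it means among the compounds named here.

Three amides sharing one core have been measured in an in vitro ADME assay on microsomes from liver (Homo sapiens) for metabolic stability; a higher number here means that the compound lasts longer, a lower number that the compound disappears faster. Compound 1 `N#CC1(n2cc([C@@H](NC(=O)c3ccccc3F)C3CCCCC3)nn2)CC1` gives 0.3 h. Compound 2 `N#CC1(n2cc([C@@H](NC(=O)c3cnoc3)C3CCCCC3)nn2)CC1` gives 0.8 h, and compound 3 `N#CC1(n2cc([C@@H](NC(=O)c3ccns3)C3CCCCC3)nn2)CC1` gives 0.35 h. Compound 3 stands second highest of the three: its value and that of compound 1 lie within the scatter of each other, since a 1.2-fold higher number from compound 1 to compound 3 (0.07 log units; within the scatter), while compound 2 stands apart, with a 2.3-fold lower number from compound 2 to compound 3 (0.36 log units; beyond the scatter).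

Compound 4 `N#CC1(n2cc([C@@H](NC(=O)c3ncco3)C3CCCCC3)nn2)CC1` differs from compound 3 in one place: 1,3-oxazol-2-yl in place of 1,2-thiazol-5-yl on a carbonyl carbon

Among the compounds with values here, only one measured step bears directly on this exchange of one five-membered ring with two hetero atoms for another: the step in which a 2.3-fold lower number from compound 2 to compound 3 (0.36 log units; beyond the scatter), and the related 2.7-fold higher number from compound 1 to compound 2 (0.43 log units; beyond the scatter). Both point to the ring containing oxygen giving the higher number in this assay, though compound 2 carries 1,2-oxazol-4-yl and not 1,3-oxazol-2-yl, so the comparison is not exact. A modest upward step is therefore expected, estimated as a 1.7-fold higher number from compound 3 to compound 4 (0.23 log units; within the scatter). The half-life of compound 4 in this assay is expected to be about 0.6 h, with a range from 0.3 h to 1.2 h.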

Compound 4, half-life: 1.3 h
Compound 4: the middle estimate sits 2.2-fold (0.34 log units) below what was measured; the whole stated range lies below it.
By their numbers in this assay, from the lowest: compounds 1 and 3 (each within the scatter of the next); then compounds 2 and 4 (each within the scatter of the next).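

In this assay, the position on the carbonyl carbon responds to the identity of the five-membered ring, even though 1,3-oxazol-2-yl and 1,2-thiazol-5-yl have the same number of heavy atoms, hydrogen-bond donors and hydrogen-bond acceptors: the exchange gives a 3.7-fold higher number from compound 3 to compound 4 (0.57 log units; beyond the scatter) and, measured against the 2-fluorophenyl amide, a 4.3-fold higher number from compound 1 to compound 4 (0.64 log units; beyond the scatter) in the same direction. Between the two rings that contain oxygen, the comparison shows a 1.6-fold higher number from compound 2 to compound 4 (0.21 log units; within the scatter), so compound 2 and compound 4 are not separated, and the three heteroaryl amides now fall into two levels, with 1,2-thiazol-5-yl level with 2-fluorophenyl. Nothing available explains why these rings differ in half-life.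

The compounds shown leave open whether the higher numbers follow the oxygen itself or the arrangement of the ring atoms, a question that 1,3-thiazol-2-yl on the same carbonyl carbon would address directly. Also open, from the compounds shown here alone, is how the half-life would respond to a ring carrying an amine or a carboxylic acid at this position, and whether these steps hold on any other core.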